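A Ring Swap on a Weak Bile Acid Receptor Antagonist

A few compounds are considered here, and "the series" means these few. Any claim that something is new, unique, unknown or untested is made for them only; others in the source may bear on it.

Of the compounds shown here, two have so far been measured in an assay on isolated protein for antagonist activity at Bile acid receptor (Homo sapiens), read by HTRF, with a stated time of 30 min; a lower number here means a stronger inhibitor, a higher number a weaker inhibitor. Compound 1 `CC(C)(C)c1cc(OC(=O)c2c(Cl)cc([N+](=O)[O-])cc2Cl)ccc1O` gives 5900 nM in this assay. Compound 2 `CC(C)(C)c1cc(NC(=O)c2c(Cl)cc(NCc3cccs3)cc2Cl)ccc1O` gives 8600 nM in this assay. Compound 2 has the higher of the two numbers, but its gap to compound 1 lies within the scatter of repeated measurements, so the two cannot be told apart on these data; both sit in the weak range.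

Compound 3 `CC(C)(C)c1cc(NC(=O)c2c(Cl)cc(N3CCNCC3)cc2Cl)ccc1O` is compound 2 with one alteration: piperazin-1-yl in place of ((thiophen-2-yl)methyl)amino on an aromatic carbon. Among the measured compounds shown here, no pair of measured compounds shows an exchange of this kind, so the size of the step has to be estimated rather than read off. Both measured compounds are weak, and nothing in the data points to a large gain or loss from this swap. The expected step from compound 2 to compound 3 is a 1.2-fold higher number from compound 2 to compound 3 (0.07 log units; within the scatter), which amounts to no change beyond the scatter. Compound 3 is therefore estimated at 10000 nM in this assay, with a likely range from 3500 nM to 30000 nM.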

Compound 3, half-maximal inhibitory concentration: > 100000 nM
Compound 3 gave a limit, no number; the forecaster's own chance of this, stated with the estimate: 25%; middle value at least 10-fold (1.00 log units) from the limit.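

In this assay, compound 3 returns a limit and not a number: the limit of > 100000 nM in this assay, at which 1 of the 3 values shown sits.

Even so, the exchange of ((thiophen-2-yl)methyl)amino for piperazin-1-yl, on the aromatic carbon para to a large group and meta to two chloro groups, gives an at least 11-fold higher number from compound 2 to compound 3 (1.06 log units; beyond the scatter), so the group at this position can strongly change the read-out, which the earlier compounds could not show since they differ in more than one place. The two groups have the same counts of hydrogen-bond donors and acceptors and no net charge, so those counts alone do not separate them, while the aromatic five-membered ring with its sulfur and the non-aromatic six-membered ring with its second nitrogen do differ.

On these data alone, the true size of this step remains unknown, since one end of it is a limit, and a single exchange cannot show which feature of the piperazin-1-yl group goes with the loss. A benzylamino group, which keeps the amino link and an aromatic ring, or a morpholin-4-yl group, which keeps a non-aromatic six-membered ring with oxygen in place of the second nitrogen, would help to separate these features.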